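Aryl ether ureas: chloro, methoxy, chloro-fluoro

The source may hold more compounds than are shown below. What is called first, only, known or untested is meant among the compounds shown, and "the series" means these compounds.

compound 1, `CNC(=O)c1cccc(NC(=O)N2CCC(Oc3ccccc3Cl)CC2)c1`: < 4 nM in an assay on isolated protein for inhibition of acyl-CoA desaturase 1 (Mus musculus); a lower number here means a stronger inhibitor, a higher number a weaker inhibitor
compound 2, `CNC(=O)c1cccc(NC(=O)N2CCC(Oc3ccccc3OC)CC2)c1`: 81 nM in this assay

For compound 1 the value is a limit of the assay, not a number, namely (the limit of < 4 nM in this assay, at which 1 of the 2 values shown sits). Compound 2 gives the only plain number shown. Compound 3, `CNC(=O)c1cccc(NC(=O)N2CCC(Oc3c(F)cccc3Cl)CC2)c1`, is not yet measured: 2-chloro-6-fluorophenyl in place of 2-methoxyphenyl on an oxygen on a saturated carbon. Within the data shown here, the one measured step, an at least 20-fold higher number from compound 1 to compound 2 (1.30 log units; beyond the scatter), bears directly on this change, since compound 3 again carries the chloro of compound 1 and adds a fluorine. A large fall in the number, back toward the limit, is therefore expected, a 27-fold lower number from compound 2 to compound 3 (1.43 log units; beyond the scatter). Compound 3 is estimated at 3 nM (1 nM to 15 nM), with a fair chance that only a limit is reported.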

Compound 3, half-maximal inhibitory concentration: 330 nM
The estimate for compound 3 lay 110-fold (2.04 log units) below the measured number, and the stated range ends below it.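

A single fluoro in place of hydrogen on an aromatic carbon is costly at this position, giving an at least 82-fold higher number from compound 1 to compound 3 (1.91 log units; beyond the scatter). The chloro alone therefore does not secure strength here: 2-chloro-6-fluorophenyl in place of 2-methoxyphenyl gives a 4.1-fold higher number from compound 2 to compound 3 (0.61 log units; beyond the scatter). The value for compound 1 is a limit of the assay, so the size of the fluoro step is only a bound: the limit of < 4 nM in this assay, at which 1 of the 3 values shown sits.

Still open, going by these compounds, is whether a methyl or a bromo in place of this fluoro brings the same loss. Also open, on these data alone, is how a fluoro without the chloro behaves on the same phenyl ring.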